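From 2-fluorophenyl to 3-fluorophenyl: the step to compound 4

The source may hold more compounds than are shown below. What is called first, only, known or untested is meant among the compounds shown, and "the series" means these compounds.

Going by the values given here, in a physicochemical assay for lipophilicity, at pH 7.4 (on this read-out lower numbers stand for lower lipophilicity and higher numbers for higher lipophilicity), three compounds have numbers so far. Compound 1 `Cc1cc(COc2ccc(Cl)cc2)nc(-c2ccccn2)n1` reads 3.7 and compound 2 `COc1cccc(OCc2cc(C)nc(-c3ccccn3)n2)c1` reads 2.9 on this scale. Compound 3 `Cc1cc(COc2ccccc2F)nc(-c2ccccn2)n1` reads 2.9 here, level with compound 2 and together with it the lowest of the three.

Compound 4 `Cc1cc(COc2cccc(F)c2)nc(-c2ccccn2)n1` has no number yet. It carries 3-fluorophenyl in place of 2-fluorophenyl on an oxygen on a saturated carbon, a change counted as 3-fluorophenyl in place of 2-fluorophenyl on an oxygen on a saturated carbon in which the two compounds have the same atoms, joined differently.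

Among the compounds with values here, one measured step touches that place: the step of a number 0.80 log units lower from compound 1 to compound 3 (beyond the scatter) came with 2-fluorophenyl in place of 4-chlorophenyl. Within the data shown here, that step changed the atoms as well, so it sets no size for this move, and no measured pair shows a shift of the fluorine alone. Compound 3 at 2.9 is therefore the anchor. The step expected in this assay is a number 0.10 log units higher from compound 3 to compound 4 (within the scatter) and none beyond the scatter is anticipated. For compound 4 the estimate is 3 with 2.6 to 3.4 as the expected range.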

Compound 4, distribution coefficient: 3.1
For compound 4 the middle estimate is 0.10 log units below the measured one; measured number inside the range.
By their numbers in this assay, from the lowest: compounds 2, 3 and 4 (each within the scatter of the next); then compound 1.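

In this assay, going by these compounds alone, the first pair to differ only in where the fluorine sits, 3-fluorophenyl in place of 2-fluorophenyl on an oxygen on a saturated carbon, shows a number 0.20 log units higher from compound 3 to compound 4 (within the scatter), so between these two compounds the move does not register beyond the scatter. Fluoro in place of methoxy on an aromatic carbon likewise gives a number 0.20 log units higher from compound 2 to compound 4 (within the scatter), whereas 3-fluorophenyl in place of 4-chlorophenyl gives a number 0.60 log units lower from compound 1 to compound 4 (beyond the scatter), so both fluorophenyl compounds now stand beyond the scatter from compound 1. Nothing available offers an explanation for these numbers.

The compounds shown leave open how the read-out would stand with an amine or a carboxylic acid on this aromatic ring. Within the data shown here, no pair changes the halogen alone, so the step from compound 1 cannot be divided between the change of halogen and the shift of its site.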